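The source may report more compounds than this note shows. Statements on the series, on what has been measured and on what is new or still open speak of the compounds shown alone.

Measured compounds in an assay on cell membranes for binding affinity to 2-oxoglutarate receptor 1 (Rattus norvegicus), read by radioligand binding; on this read-out higher numbers stand for weaker inhibition and lower numbers for stronger inhibition:
- compound 1 `CCCCCCCNC(=O)[C@H]1OC(n2cnc3c(N)ncnc32)[C@H](O)[C@@H]1O`: 20 nM
- compound 2 `CCCCCCCCNC(=O)[C@H]1OC(n2cnc3c(N)ncnc32)[C@H](O)[C@@H]1O`: 21 nM
- compound 3 `CCCCCCCCCCCNC(=O)[C@H]1OC(n2cnc3c(N)ncnc32)[C@H](O)[C@@H]1O`: 123 nM

The series lengthens the amide-type chain. From compound 1 to compound 2 the change is methyl in place of hydrogen on a saturated chain carbon, seven bonds along the chain from an amide-type nitrogen, and it gives a 1.1-fold higher number from compound 1 to compound 2 (0.02 log units; within the scatter). Further lengthening, (butyl in place of hydrogen on a saturated chain carbon, seven bonds along the chain from an amide-type nitrogen), gives a 6.2-fold higher number from compound 1 to compound 3 (0.79 log units; beyond the scatter), and a 5.9-fold higher number from compound 2 to compound 3 (0.77 log units; beyond the scatter) points the same way.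

Compound 4 `CCCCCCCCCCCCNC(=O)[C@H]1OC(n2cnc3c(N)ncnc32)[C@H](O)[C@@H]1O` is not yet measured. It differs from compound 3 by methyl in place of hydrogen on a saturated chain carbon, ten or more bonds along the chain from an amide-type nitrogen. The cores differ by butyl in place of hydrogen on a saturated chain carbon, seven bonds along the chain from an amide-type nitrogen; the place along the chain differs too, as the two difference descriptions show, so it is the same kind of change, not the same. Because a 1.1-fold higher number from compound 1 to compound 2 (0.02 log units; within the scatter) was flat while a 5.9-fold higher number from compound 2 to compound 3 (0.77 log units; beyond the scatter) weakened, a small loss is expected, a 1.6-fold higher number from compound 3 to compound 4 (0.21 log units; within the scatter). For compound 4 in this assay the estimate is 200 nM, between 100 nM and 450 nM.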

Compound 4, inhibition constant: 163 nM
Estimate against measurement, compound 4: 1.2-fold (0.09 log units) above; the measured number falls inside the stated range.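

In this assay, the methyl step gives a 1.3-fold higher number from compound 3 to compound 4 (0.12 log units; within the scatter), which agrees with the earlier methyl step: the same change on two cores in this assay, a 1.1-fold higher number (0.02 log units; within the scatter) from compound 1 to compound 2 and a 1.3-fold higher number (0.12 log units; within the scatter) from compound 3 to compound 4, 1.3-fold (0.10 log units) apart, within the scatter of two such steps. The larger extension gives a 7.8-fold higher number from compound 2 to compound 4 (0.89 log units; beyond the scatter), which agrees with its earlier counterpart: the same change on two cores in this assay, a 6.2-fold higher number (0.79 log units; beyond the scatter) from compound 1 to compound 3 and a 7.8-fold higher number (0.89 log units; beyond the scatter) from compound 2 to compound 4, 1.3-fold (0.10 log units) apart, within the scatter of two such steps. The full span is an 8.2-fold higher number from compound 1 to compound 4 (0.91 log units; beyond the scatter), so each change carries over between these straight-chain cores, but the cores differ only in chain length, and this shows nothing about a core that differs in any other way.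

Still open, from the compounds shown here alone, is whether the number keeps rising or levels off with a longer chain than that of compound 4. Going by these compounds, the effect of an amine or a carboxylic acid on the chain is also open.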